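Sulfonamide aryl variation at a shared core: working notes

This account rests on a few compounds, and the source may have more. Where it says the series, first, only, none or still open, it means among the compounds named here.

Compound 1 `COc1cccc(S(=O)(=O)NC2=NCCN2C(=S)SN2CCn3c2nsc3=S)c1`: in a functional assay on KYSE-510 cells (Homo sapiens) for antiproliferative activity, read by crystal violet staining, with a stated time of 96 h (a higher number here means a weaker inhibitor of growth, a lower number a stronger inhibitor of growth), a limit of the assay, >= 20000 nM.
Compound 2 `O=S(=O)(NC1=NCCN1C(=S)SN1CCn2c1nsc2=S)c1ccc(Cl)c(Cl)c1`: in this assay a limit of the assay, >= 20000 nM.
Compound 3 `O=S(=O)(NC1=NCCN1C(=S)SN1CCn2c1nsc2=S)c1ccc(Cl)c(Cl)c1Cl`: in this assay a limit of the assay, >= 20000 nM.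

Compound 3 therefore stands at the limit of >= 20000 nM in this assay, at which 3 of the 3 values shown sit, as do the other two, and the steps a step that the two limits leave unreadable from compound 1 to compound 2, a step that the two limits leave unreadable from compound 1 to compound 3 and a step that the two limits leave unreadable from compound 2 to compound 3 cannot be sized. Compound 4 `O=S(=O)(NC1=NCCN1C(=S)SN1CCn2c1nsc2=S)c1ccc(F)c(Cl)c1` differs by 3-chloro-4-fluorophenyl in place of 2,3,4-trichlorophenyl on a sulfonyl sulfur. For the measured compounds named here, no measured step bears readably on this change; every comparison among the three measured compounds ends at the limit, so no direction can be taken from them. Compound 4 is expected to give 25000 nM, with a range of 8000 nM to 80000 nM, most probably again only a limit. The expected step is thus a step that the limit leaves unreadable from compound 3 to compound 4, none beyond the scatter.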

Compound 4, concentration for 50% growth inhibition: >= 20000 nM
Compound 4 ended at the assay's limit; the forecaster's own chance of this, stated with the estimate: 85%; the middle value lies beyond the limit too.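

No step to compound 4 from compound 1, compound 2 or compound 3 can be read in this assay, as all four compounds end at a limit: the limit of >= 20000 nM in this assay, at which 4 of the 4 values shown sit.

As far as these compounds go, how these groups on the sulfonyl sulfur rank in growth inhibition remains open.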